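The source may report more compounds than this note shows. Statements on the series, on what has been measured and on what is new or still open speak of the compounds shown alone.

Compound 1 `Clc1ccc(C2CC(c3ccc(N4CCCCC4)cc3)=NN2c2nc(-c3ccccc3)cs2)cc1` is one of three close analogues that share a core and differ only in a group on one phenyl ring. In a functional assay on A549 cells (Homo sapiens) for antiproliferative activity, read by MTT assay, with a stated time of 72 h (a higher number here means a weaker inhibitor, a lower number a stronger inhibitor), compound 1 gives 64200 nM, the highest of the three numbers, though its gaps to the other two stay within the scatter. Compound 2 `Clc1ccc(-c2csc(N3N=C(c4ccc(N5CCCCC5)cc4)CC3c3ccc(Cl)cc3)n2)cc1` gives 46400 nM in this assay, and compound 3 `Clc1ccc(C2CC(c3ccc(N4CCCCC4)cc3)=NN2c2nc(-c3ccc(Br)cc3)cs2)cc1` gives 39700 nM. The step of a 1.4-fold lower number from compound 1 to compound 2 (0.14 log units; within the scatter) and the step of a 1.6-fold lower number from compound 1 to compound 3 (0.21 log units; within the scatter) both fall within the scatter, as does a 1.2-fold lower number from compound 2 to compound 3 (0.07 log units; within the scatter), so exchanging hydrogen for a halogen at this site did nothing that can be told from noise.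

Compound 4 `COc1ccc(-c2csc(N3N=C(c4ccc(N5CCCCC5)cc4)CC3c3ccc(Cl)cc3)n2)cc1` carries the change methoxy in place of hydrogen on an aromatic carbon at the same place. Since the two measured changes at this site left the number essentially unchanged, the expected step of a 1.3-fold lower number from compound 1 to compound 4 (0.11 log units; within the scatter) is none beyond the scatter. Compound 4 is therefore estimated to give 50000 nM in this assay, within a range from 25000 nM to 100000 nM.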

Compound 4, half-maximal inhibitory concentration: > 100000 nM
Compound 4 was reported as a limit; the forecaster's own chance of this, stated with the estimate: 10%; middle value at least 2.0-fold (0.30 log units) from the limit.
By their numbers in this assay, from the lowest: compounds 3, 2 and 1 (each within the scatter of the next). At a limit, above all of these: compound 4.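

In this assay compound 4 is reported only as a limit, not as a number: the limit of > 100000 nM in this assay, at which 1 of the 4 values shown sits.

Even so, this position proves not to be indifferent to what sits on it, since replacing a halogen with methoxy gives an at least 2.5-fold higher number from compound 3 to compound 4 (0.40 log units; beyond the scatter) and an at least 2.1-fold higher number from compound 2 to compound 4 (0.33 log units; beyond the scatter), a separation that the halogens and hydrogen never showed among themselves. Against plain hydrogen the reading is less firm, at an at least 1.5-fold higher number from compound 1 to compound 4 (0.19 log units; that floor lies within the scatter), so this comparison alone does not establish a real loss.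

The compounds shown give no reason for the difference, and how far the true number of compound 4 lies past its limit stays unknown. Going by these compounds, whether a hydroxyl, an amine or a longer ether such as ethoxy at this place would follow methoxy or the halogens also remains open.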